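Series notes: amino in place of methyl on the five-membered ring

The source may hold more compounds than are shown below. What is called first, only, known or untested is meant among the compounds shown, and "the series" means these compounds.

Measured compounds in a functional assay on MDA-MB-435S cells (Homo sapiens) for cytotoxicity, read by MTT assay, with a stated time of 72 h; on this read-out higher numbers stand for weaker inhibition and lower numbers for stronger inhibition:
compound 1 `Nc1nnc(SCc2cc(=O)c3ccccc3o2)s1` – > 25000 nM
compound 2 `Nc1nnc(SCc2cc(=O)c3cc(Cl)ccc3o2)s1` – > 25000 nM
compound 3 `Cc1ccc2oc(CSc3nnc(C)s3)cc(=O)c2c1` – > 25000 nM

Compound 3 gives only a limit in this assay, not a number. The same holds for compound 1 and compound 2, so all three values shown sit at the limit (the limit of > 25000 nM in this assay, at which 3 of the 3 values shown sit). Among the compounds with values here, the one step between measured compounds, a step that the two limits leave unreadable from compound 1 to compound 2, is therefore unreadable, and nothing orders the three compounds.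

Compound 4 `Cc1ccc2oc(CSc3nnc(N)s3)cc(=O)c2c1` is the not yet measured analogue of compound 3; the change is amino in place of methyl on an aromatic carbon. Within the data shown here, no measured step covers this change directly. The nearest evidence is compound 1, which already carries the amino group on the same ring and gives > 25000 nM in this assay, a limit. With every value shown sitting at the limit, compound 4 is expected to sit there as well: the estimate is 40000 nM, with a range of 15000 nM to 150000 nM. The expected step that the limit leaves unreadable from compound 3 to compound 4 is therefore none beyond the scatter, with the number most likely reported only as a limit.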

Compound 4, half-maximal inhibitory concentration: > 25000 nM
Compound 4 gave a limit, no number (the forecaster's own chance of this, stated with the estimate: 85%); the middle value is on the limit's open side.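

In this assay compound 4 gives > 25000 nM as a limit and not a number, and its steps from compound 1, compound 2 and compound 3 cannot be read: the limit of > 25000 nM in this assay, at which 4 of the 4 values shown sit.

The compounds shown leave open whether amino and methyl differ at all on this read-out, and whether any change to the shared core gives a measurable value.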